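This account rests on a few compounds, and the source may have more. Where it says the series, first, only, none or still open, it means among the compounds named here.

Compounds measured so far in a functional assay on LNCaP cells (Prostate gland, Homo sapiens) for antiproliferative activity, read by sulforhodamine B assay; a lower number here means a stronger inhibitor, a higher number a weaker inhibitor:
compound 1 `CCCCCCCCCCCCCCCCCCNC(=O)[C@H]1CSC(c2c[nH]c3ccccc23)N1`: 2100 nM
compound 2 `CCCCCCCCCCCCCCCCCCNC(=O)[C@H]1CSC(c2ccc(F)cc2)N1`: 1900 nM
compound 3 `CCCCCCCCCCCCCCCCCCNC(=O)[C@H]1CSC(c2c(Cl)cccc2Cl)N1`: 13100 nM

Compound 1 stands second highest of the three numbers, with compound 2 nearest and compound 3 furthest. Compound 4 `CCCCCCCCCCCCCCCCCCNC(=O)[C@H]1CSC(c2ccc(C)cc2)N1` carries 4-methylphenyl in place of 1H-indol-3-yl on a saturated ring carbon. Two measured steps from compound 1 bear on this change. The step of a 1.1-fold lower number from compound 1 to compound 2 (0.04 log units; within the scatter) lies within the scatter, while a 6.2-fold higher number from compound 1 to compound 3 (0.80 log units; beyond the scatter) lies beyond it; the step of a 6.9-fold higher number from compound 2 to compound 3 (0.84 log units; beyond the scatter) shows the same separation. The group entering in compound 4, a six-membered aromatic ring of carbon only, resembles the 4-fluorophenyl of compound 2 far more than the 2,6-dichlorophenyl of compound 3, so no step beyond the scatter is expected in this assay; the estimated step is a 1.1-fold lower number from compound 1 to compound 4 (0.02 log units; within the scatter). For compound 4 the expected value in this assay is 2000 nM, with a range from 900 nM to 4500 nM.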

Compound 4, half-maximal inhibitory concentration: 1900 nM
Estimate against measurement, compound 4: 1.1-fold (0.02 log units) above; the range from low to high includes it.
By their numbers in this assay, from the lowest: compounds 2, 4 and 1 (each within the scatter of the next); then compound 3.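

In this assay, a third aryl group stays level with the others: a 1.1-fold lower number from compound 1 to compound 4 (0.04 log units; within the scatter) is a step within the scatter, and no change at the digits printed from compound 2 to compound 4 (within the scatter) shows that methyl in place of fluoro on an aromatic carbon has no measurable effect here. Compound 3 remains the exception, with a 6.9-fold lower number from compound 3 to compound 4 (0.84 log units; beyond the scatter) marking a step beyond the scatter. Nothing available explains this separation.

Still open, as far as these compounds go, is whether a single chlorine on the phenyl ring would stay level with compound 4 or follow compound 3. From the compounds shown here alone, an amine or a carboxylic acid in place of the methyl also remains untested in these data.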